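The source may report more compounds than this note shows. Statements on the series, on what has been measured and on what is new or still open speak of the compounds shown alone.

Compound 1 `CCCCN(CC)Cc1c(C(F)(F)F)nc2n(-c3c(C)cc(C)cc3C)c(Cl)cn12` gives 78 nM in an assay on cells for displacement of a labelled ligand from corticotropin-releasing factor receptor 1 (Homo sapiens), with a stated time of 100 min; on this read-out lower numbers stand for stronger inhibition and higher numbers for weaker inhibition.
Compound 2 `Cc1cc(C)c(-n2c(Cl)cn3c(CN(CCC(F)(F)F)Cc4ccccc4)c(C(F)(F)F)nc23)c(C)c1` gives 43 nM in this assay.
Compound 3 `Cc1cc(C)c(-n2c(Cl)cn3c(CN(C)Cc4ccccc4)c(C(F)(F)F)nc23)c(C)c1` gives 160 nM in this assay.

Compound 1 holds the second highest of the three numbers; its value and that of compound 2 lie within the scatter of each other, while the step to compound 3 is a 2.1-fold higher number from compound 1 to compound 3 (0.31 log units; beyond the scatter). Compound 4 `CCCN(Cc1ccccc1)Cc1c(C(F)(F)F)nc2n(-c3c(C)cc(C)cc3C)c(Cl)cn12` differs from compound 1 by benzyl(propyl)amino in place of butyl(ethyl)amino on a saturated chain carbon bound to an aromatic carbon. Among the compounds with values here, two measured steps bear on this. Exchanging butyl(ethyl)amino for benzyl(methyl)amino gave a 2.1-fold higher number from compound 1 to compound 3 (0.31 log units; beyond the scatter), whereas adding a larger group at the amine nitrogen beside benzyl gave a 3.7-fold higher number from compound 2 to compound 3 (0.57 log units; beyond the scatter) in reverse. A propyl beside benzyl is therefore expected to roughly offset these effects, giving a step of a 1.4-fold lower number from compound 1 to compound 4 (0.15 log units; within the scatter) toward a lower number. Compound 4 is estimated at 55 nM, with a range from 25 nM to 120 nM.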

Compound 4, inhibition constant: 170 nM
Beside the measured number, compound 4's estimate is 3.1-fold (0.49 log units) below it; the measured number lies above the stated range.
By their numbers in this assay, from the lowest: compounds 2 and 1 (each within the scatter of the next); then compounds 3 and 4 (each within the scatter of the next).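

With benzyl on the amine, exchanging methyl for propyl leaves the number within the scatter (a 1.1-fold higher number from compound 3 to compound 4 (0.03 log units; within the scatter)), while benzyl(propyl)amino reads weaker than butyl(ethyl)amino (a 2.2-fold higher number from compound 1 to compound 4 (0.34 log units; beyond the scatter)). The end of the chain counts for more here: methyl in place of trifluoromethyl gives the largest step of the set (a 4.0-fold higher number from compound 2 to compound 4 (0.60 log units; beyond the scatter)), so the gain seen with compound 2 is not shared by the plain propyl chain. No measurement at hand explains this difference. From the compounds shown here alone, whether a longer chain ending in trifluoromethyl, or a chain ending in a nitrile or hydroxyl, would match compound 2 remains open.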